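Nitro in Place of Iodo: What Compound 4 Might Give

This account rests on a few compounds, and the source may have more. Where it says the series, first, only, none or still open, it means among the compounds named here.

Compound 1 `CC(=NNC(=S)Nc1cccc(I)c1)c1ccccn1` gives 61 nM in a functional assay on T98G cells (Homo sapiens) for cytotoxicity, read by MTT assay, with a stated time of 48 h; on this read-out lower numbers stand for stronger inhibition and higher numbers for weaker inhibition. Compound 2 `C/C(=N\NC(=S)Nc1cccc(I)c1)c1ccccn1` gives 61 nM in this assay, and compound 3 `CC(=NNC(=S)Nc1ccc(I)cc1)c1ccccn1` gives 64 nM in this assay. Going by the values given here, the one step measured here, no change at the digits printed from compound 1 to compound 2 (within the scatter), is a step between two drawings of the same atoms and bonds, which fits with the fact that one of compounds 1 and 2 is drawn with a defined configuration and the other without, at the place where they differ. Compound 2 thus stands level with compound 1, with compound 3 within the scatter of both, so none of the three can be called the most potent.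

Compound 4 `C/C(=N\NC(=S)Nc1cccc([N+](=O)[O-])c1)c1ccccn1` differs from compound 2 by nitro in place of iodo on an aromatic carbon. Among the compounds with values here, no measured step touches this change: the only step measured is a change of drawing, and the values of compound 2 and compound 3 show only that moving the iodo stays within the scatter. The size of a 1.6-fold higher number from compound 2 to compound 4 (0.21 log units; within the scatter) is therefore expected to be small, with no firm direction. Compound 4 is estimated at 100 nM in this assay, within a range from 30 nM to 400 nM.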

Compound 4, half-maximal inhibitory concentration: 140 nM
Estimate against measurement, compound 4: 1.4-fold (0.15 log units) below, within the range that was stated.
By their numbers in this assay, from the lowest: compounds 1, 2 and 3 (each within the scatter of the next); then compound 4.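

In this assay, going by these compounds alone, nitro in place of iodo on an aromatic carbon, meta to a large group, gives a 2.3-fold higher number from compound 2 to compound 4 (0.36 log units; beyond the scatter) and is the first step to lie beyond the scatter. This position therefore responds to the group placed on it, though only modestly, as compound 4 still stands at 140 nM in the nanomolar range. Nothing in the information available bears on why the number rises with this change.

With a single replacement shown at this position, it stays open whether the rise reflects the loss of iodo or the arrival of nitro. From the compounds shown here alone, how an amine or a carboxylic acid on the same aromatic carbon would compare with iodo and nitro also remains unknown.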